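Swapping the Aryl Group on the Amine Arm

This account rests on a few compounds, and the source may have more. Where it says the series, first, only, none or still open, it means among the compounds named here.

compound 1 `CN(C)Cc1ccc(COc2ccc3ccc(=O)oc3c2)cc1` in an assay for inhibition of Amine oxidase [flavin-containing] B (Rattus norvegicus), read by spectrophotometry (a higher number here means a weaker inhibitor, a lower number a stronger inhibitor), gives 3700 nM
compound 2 `COc1cccc(CN(C)Cc2ccc(COc3ccc4ccc(=O)oc4c3)cc2)c1` in this assay gives 2900 nM

Compound 2 stands nearest compound 1, and the step of a 1.3-fold lower number from compound 1 to compound 2 (0.11 log units; within the scatter) lies within the scatter, so neither compound can be ranked above the other. Compound 3 `CN(Cc1ccc(C#N)cc1)Cc1ccc(COc2ccc3ccc(=O)oc3c2)cc1` carries the change (4-cyanophenyl in place of 3-methoxyphenyl on a saturated chain carbon bound to an amine nitrogen). For the measured compounds named here, the only measured step that bears on it, the addition of the 3-methoxyphenyl group, was a 1.3-fold lower number from compound 1 to compound 2 (0.11 log units; within the scatter) and did not leave the scatter, so the estimated step of a 1.0-fold higher number from compound 2 to compound 3 (0.01 log units; within the scatter) is expected to be none beyond the scatter. Compound 3 is therefore expected at 3000 nM, with a range from 1200 nM to 8000 nM.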

Compound 3, half-maximal inhibitory concentration: 270 nM
Compound 3: the middle estimate sits 11-fold (1.05 log units) above what was measured; the whole stated range lies above it.
By their numbers in this assay, from the lowest: compound 3; then compounds 2 and 1 (each within the scatter of the next).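

Replacing 3-methoxyphenyl with 4-cyanophenyl gives an 11-fold lower number from compound 2 to compound 3 (1.03 log units; beyond the scatter) in this assay and shows that this place, on a saturated chain carbon bound to an amine nitrogen, is sensitive to which aryl group it carries. Compared with hydrogen, 4-cyanophenyl gives a 14-fold lower number from compound 1 to compound 3 (1.14 log units; beyond the scatter) while 3-methoxyphenyl stayed within the scatter, so adding an aryl group here does not by itself account for the change. The compounds shown leave open whether the gain follows the nitrile or its place on the ring, which 3-cyanophenyl and 4-methoxyphenyl on the same carbon could separate. Nothing available here explains the size of this step.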